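The source may hold more compounds than are shown below. What is called first, only, known or untested is meant among the compounds shown, and "the series" means these compounds.

For the measured compounds named here, compound 3 `Cn1c(=O)c2nc(-c3ccc(-c4ccccc4)cc3)[nH]c2n(C)c1=O` stands highest of the three numbers so far in an assay for binding affinity to adenosine receptor A1 (Bos taurus) (on this read-out lower numbers stand for stronger inhibition and higher numbers for weaker inhibition), where compound 3 gives 3.5 nM; compound 1 `Cn1c(=O)c2nc(-c3ccc(Cl)cc3)[nH]c2n(C)c1=O` gives 0.8 nM and compound 2 `Cn1c(=O)c2nc(-c3ccc(I)cc3)[nH]c2n(C)c1=O` gives 1.3 nM. The next member is compound 4 `CCOc1ccc(-c2nc3c(=O)n(C)c(=O)n(C)c3[nH]2)cc1`, which differs from compound 3 by ethoxy in place of phenyl on an aromatic carbon. Going by the values given here, two measured steps bear on the loss of the phenyl: a 4.4-fold higher number from compound 1 to compound 3 (0.64 log units; beyond the scatter) and a 2.7-fold higher number from compound 2 to compound 3 (0.43 log units; beyond the scatter), both modest rises when the phenyl entered in place of a halogen. Ethoxy is neither halogen, so the step back is uncertain in size; a modest fall, or no step beyond the scatter, is expected for this assay, as a 1.8-fold lower number from compound 3 to compound 4 (0.24 log units; within the scatter). Compound 4 is therefore estimated at 2 nM, with a range from 0.7 nM to 6 nM.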

Compound 4, half-maximal inhibitory concentration: 2 nM
For compound 4 middle estimate and measured number coincide at the digits printed; measured number inside the range.
By their numbers in this assay, from the lowest: compounds 1, 2, 4 and 3 (each within the scatter of the next, the first and the last beyond it).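

At this position, para to a large group, ethoxy brings no ring yet stays level with the larger phenyl in this assay, with a 1.8-fold lower number from compound 3 to compound 4 (0.24 log units; within the scatter), and level with iodo, with a 1.5-fold higher number from compound 2 to compound 4 (0.19 log units; within the scatter). Only chloro separates from it, with a 2.5-fold higher number from compound 1 to compound 4 (0.40 log units; beyond the scatter), a modest step. No measurement here accounts for these steps.

As far as these compounds go, whether an amine, a carboxylic acid or a longer alkoxy chain at this position would stay level with compound 4 remains open.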